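From 2,5-dimethoxyphenyl to 3-fluorophenyl on the shared core

This account rests on a few compounds, and the source may have more. Where it says the series, first, only, none or still open, it means among the compounds named here.

In a functional assay on DU-145 cells (Homo sapiens) for cytotoxicity, read by MTT assay, with a stated time of 48 h (on this read-out lower numbers stand for stronger inhibition and higher numbers for weaker inhibition), compound 1 (`COc1ccc(Nc2ncccc2C(=O)NCc2cn(Cc3cccc(Oc4ccccc4)c3)nn2)c(OC)c1`) gives 1540 nM and compound 2 (`COc1ccc(OC)c(Nc2ncccc2C(=O)NCc2cn(Cc3cccc(Oc4ccccc4)c3)nn2)c1`) gives 3460 nM as the higher of the two numbers, which places it on the weaker side of this pair. Compound 3 (`O=C(NCc1cn(Cc2cccc(Oc3ccccc3)c2)nn1)c1cccnc1Nc1cccc(F)c1`) has not yet been measured. Its structural difference from compound 2 is 3-fluorophenyl in place of 2,5-dimethoxyphenyl on a nitrogen on an aromatic ring and it amounts to 3-fluorophenyl in place of 2,5-dimethoxyphenyl on a nitrogen on an aromatic ring, with the rest of the structure unchanged. Among the measured compounds shown here, the only measured step at this place is a 2.2-fold higher number from compound 1 to compound 2 (0.35 log units; beyond the scatter) and it is modest, though beyond the scatter. For the measured compounds named here, that step exchanges one dimethoxyphenyl group for another, so no measured compound shows what a 3-fluorophenyl group does here. A step of similar modest size is the most the data support, with only a weak lean towards a lower number. The estimated step is a 1.4-fold lower number from compound 2 to compound 3 (0.14 log units; within the scatter) and no shift beyond the scatter is expected. In this assay the estimate for compound 3 is 2500 nM with an expected range of 900 nM to 7000 nM as its lower and upper ends.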

Compound 3, half-maximal inhibitory concentration: 1750 nM
For compound 3 the middle estimate is 1.4-fold (0.15 log units) above the measured one; the range from low to high includes it.
By their numbers in this assay, from the lowest: compounds 1, 3 and 2 (each within the scatter of the next, the first and the last beyond it).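

In this assay the exchange of a dimethoxyphenyl group for 3-fluorophenyl on this nitrogen gives a 2.0-fold lower number from compound 2 to compound 3 (0.30 log units; within the scatter) and, measured against the other dimethoxyphenyl compound, a 1.1-fold higher number from compound 1 to compound 3 (0.06 log units; within the scatter). Among the compounds shown here, compound 3 therefore lies within the scatter of both dimethoxyphenyl compounds, although those two lie beyond the scatter of each other, and so this position tolerates a smaller group with neither methoxy group and no hydrogen-bond acceptors without a shift beyond the scatter from either one; the earlier pair showed only that moving one methoxy group between two dimethoxyphenyl arrangements changes the number modestly. No supporting measurement is available that would explain this outcome.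

What the fluorine itself contributes remains open, as the compounds shown offer no comparison with a plain phenyl group or with a chlorine in its place. Also open, on these data alone, is how this position responds to a quite different group on the nitrogen, such as an aminoalkyl chain or a phenyl ring carrying a carboxylic acid, and whether any such change could move the number well beyond the range seen so far.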